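Moving the methoxy group around compound 3

A few compounds are considered here, and "the series" means these few. Any claim that something is new, unique, unknown or untested is made for them only; others in the source may bear on it.

In an ADME assay on HEL cells (Homo sapiens) for cytotoxicity, with a stated time of 3 days (on this read-out higher numbers stand for lower toxicity in this test and lower numbers for higher toxicity in this test), compound 3 `COc1cccc(-c2cc(C)cn3c(CSCCc4ccccc4)cnc23)c1` gives > 50 ug/mL, which is a limit and not a number. Compound 2 `Cc1cc(I)c2ncc(CSCCc3ccccc3)n2c1` gives > 50 ug/mL, again a limit. Compound 1 `Cc1cc(-c2ccc(O)cc2)c2ncc(CSCCc3ccccc3)n2c1` gives a true number, 13.7 ug/mL. Compound 4 `COc1ccc(-c2cc(C)cn3c(CSCCc4ccccc4)cnc23)cc1` differs from compound 3 by one swap, 4-methoxyphenyl in place of 3-methoxyphenyl on an aromatic carbon. Within the data shown here, two measured steps bear on this: an at least 3.6-fold higher number from compound 1 to compound 3 (0.56 log units; beyond the scatter) and an at least 3.6-fold higher number from compound 1 to compound 2 (0.56 log units; beyond the scatter). Among the measured groups, 4-hydroxyphenyl is the closest in name to the incoming group, so the reading for compound 1 at 13.7 ug/mL suggests some downward pull. The expected change is small and downward, an at least 1.2-fold lower number from compound 3 to compound 4 (0.09 log units; that floor lies within the scatter). Compound 4 is estimated at 40 ug/mL, with an expected range of 15 ug/mL to 70 ug/mL.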

Compound 4, half-maximal cytotoxic concentration: 19.6 ug/mL
For compound 4 the middle estimate is 2.0-fold (0.31 log units) above the measured one; the measured number falls inside the stated range.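

In this assay the move to 4-methoxyphenyl gives an at least 2.5-fold lower number from compound 3 to compound 4 (0.40 log units; beyond the scatter) even though the atoms stay the same, so where the methoxy sits on this phenyl ring matters here. Replacing iodo gives an at least 2.5-fold lower number from compound 2 to compound 4 (0.40 log units; beyond the scatter) as well, and both steps are minimum sizes, since each starts from a limit of the assay: the limit of > 50 ug/mL in this assay, at which 2 of the 4 values shown sit. Methyl in place of hydrogen on the oxygen gives a 1.4-fold higher number from compound 1 to compound 4 (0.16 log units; within the scatter) and so no readable change.

On these data alone, whether 4-aminophenyl would read like compound 1 and compound 4, or 2-methoxyphenyl like compound 3, stays open.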